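A few compounds are considered here, and "the series" means these few. Any claim that something is new, unique, unknown or untested is made for them only; others in the source may bear on it.

Measured in a physicochemical assay for solubility, at pH 7.2; a higher number here means a more soluble compound, a lower number a less soluble compound:
- compound 1 `COc1c(C(=O)Nc2ccc(NS(C)(=O)=O)cc2)cc(N2CCC(=O)NC2=O)cc1C(C)(C)C`: < 1500 nM
- compound 2 `COc1c(CNc2ccc(NS(C)(=O)=O)cc2)cc(N2CCC(=O)NC2=O)cc1C(C)(C)C`: 90800 nM
- compound 3 `COc1c(CCc2ccc(NS(C)(=O)=O)cc2)cc(N2CCC(=O)NC2=O)cc1C(C)(C)C`: 18800 nM

The entry for compound 1 is a limit and not a number. Compound 1 stands at the limit of < 1500 nM in this assay, at which 1 of the 3 values shown sits. Compound 2 and compound 3 both return numbers in this assay.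

The next structure is compound 4 `COc1c(C(=O)N(C)c2ccc(NS(C)(=O)=O)cc2)cc(N2CCC(=O)NC2=O)cc1C(C)(C)C`. It keeps the core of compound 1 and has methyl in place of hydrogen on an amide-type nitrogen. Among the compounds with values here, no measured pair isolates this change, so the expectation here is a judgement with a wide margin. An upward step beyond the usual scatter is expected in this assay, of moderate size, though a further limit remains possible. As a guide to the expected level, compound 3 gives 18800 nM, and compound 4 is not expected to pass compound 2 at 90800 nM. The estimated change is an at least 6.6-fold higher number from compound 1 to compound 4 (0.82 log units; beyond the scatter). For compound 4 the expected value is 10000 nM, with an estimated range of 2000 nM to 50000 nM.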

Compound 4, solubility: > 50000 nM
Compound 4 was reported as a limit; the forecaster's own chance of this, stated with the estimate: 20%; middle value at least 5.0-fold (0.69 log units) away from the limit.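

In this assay, methyl in place of hydrogen on the amide-type nitrogen gives an at least 33-fold higher number from compound 1 to compound 4 (1.52 log units; beyond the scatter), so on this nitrogen one added carbon, with the carbonyl kept, is enough to lift the series off its lower limit. Compound 1 remains a limit and not a number: the limit of < 1500 nM in this assay, at which 1 of the 4 values shown sits.
Compound 4 is likewise a limit and not a number: the limit of > 50000 nM in this assay, at which 1 of the 4 values shown sits.

From the compounds shown here alone, with both ends of the step being limits, its true size stays open, and compound 4 cannot be placed in order against the numbers from the compounds that lack the carbonyl. Also open, going by these compounds, is whether ethyl, a longer chain, or a chain ending in an amine on this same nitrogen would give a step of similar size.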